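Shifting the Pyridine Nitrogen Again, From Compound 2 to Compound 3

The source may report more compounds than this note shows. Statements on the series, on what has been measured and on what is new or still open speak of the compounds shown alone.

Of the compounds shown here, two sharing one core have been tested so far. Compound 1 `COc1ccc(OCc2ccccn2)c(C=O)c1` carries a pyridin-2-yl group on a saturated chain carbon bound to an oxygen on the aromatic ring, and in a functional assay on cells (Erythrocyte, Homo sapiens), with a stated time of 2 h, tested at 1 mM (a lower number here means a weaker effect, a higher number a stronger effect of the compound at the concentration tested), compound 1 gives 64.8%. Compound 2 `COc1ccc(OCc2cccnc2)c(C=O)c1` carries a pyridin-3-yl group at the same place, and in this assay compound 2 gives 59.5%. For the measured compounds named here, the only measured step, a number 5.3 percentage points lower from compound 1 to compound 2 (within the scatter), shows that moving the ring nitrogen by one position left the read-out essentially unchanged. On the numbers shown, compound 2 therefore stands alongside compound 1, separated from it only by a gap inside the scatter.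

Compound 3 `COc1ccc(OCc2ccncc2)c(C=O)c1` is the next member of the series and has not been measured. Its difference from compound 2 is pyridin-4-yl in place of pyridin-3-yl on a saturated chain carbon bound to an oxygen on an aromatic ring. Going by the values given here, the one step that bears on this change is the earlier nitrogen shift, which stayed within the scatter, so no step beyond the scatter is expected in this assay in either direction. The estimated change, a number 1.5 percentage points lower from compound 2 to compound 3 (within the scatter), is accordingly small, and compound 3 is expected to give about 58%, within a range from 44% to 70%.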

Compound 3, a percentage reported as inhibition, at one concentration (the size of the read-out at that concentration, not a potency): 60.4%
For compound 3 the middle estimate is 2.4 percentage points below the measured one; the range from low to high includes it.
By their numbers in this assay, from the lowest: compounds 2, 3 and 1 (each within the scatter of the next).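

With pyridin-4-yl at this place, all three ways of attaching a pyridine ring on a saturated chain carbon bound to an oxygen on an aromatic ring can now be compared in this assay: the new change gives a number 0.9 percentage points higher from compound 2 to compound 3 (within the scatter), and the direct comparison with the first compound gives a number 4.4 percentage points lower from compound 1 to compound 3 (within the scatter). The earlier pair showed that one shift of the ring nitrogen made no clear difference, and these steps extend that result to the full set of pyridin-2-yl, pyridin-3-yl and pyridin-4-yl, none of which can be separated from the others in this read-out. No independent measurement is available that bears on this result.

All three compounds carry a pyridine ring, so they cannot show whether the ring nitrogen contributes to the read-out at all; a plain phenyl group at the same place would address that question. As far as these compounds go, a longer chain between the oxygen and the ring, or an amine on the ring, also remains unexplored, so it is unknown how far this position tolerates changes larger than moving the nitrogen.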